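Predicting Compound 4 from a Repeated Halogen Exchange

This account rests on a few compounds, and the source may have more. Where it says the series, first, only, none or still open, it means among the compounds named here.

Compound 3 `COc1cc(Cl)cc(-c2nn(-c3cccc(NC(=O)Nc4ccc(Cl)c(C(F)(F)F)c4)c3)cc2-c2ccncc2)c1` was tested in a functional assay on SK-MEL-2 cells (Homo sapiens) for inhibition, read by sulforhodamine B assay, with a stated time of 48 h, tested at 100 uM (on this read-out lower numbers stand for a stronger effect and higher numbers for a weaker effect at the one concentration tested), where compound 3 gives -85%. Among the three measured compounds this number stands second highest: compound 1 `O=C(Nc1cccc(-n2cc(-c3ccncc3)c(-c3cc(O)cc(Cl)c3)n2)c1)Nc1ccc(Cl)c(C(F)(F)F)c1` gives -88%, a difference within the scatter, while compound 2 `O=C(Nc1cccc(-n2cc(-c3ccncc3)c(-c3cc(O)cc(Cl)c3)n2)c1)Nc1ccc(Cl)c(Cl)c1` gives -52%, a clearly weaker effect. Compound 4 `COc1cc(Cl)cc(-c2nn(-c3cccc(NC(=O)Nc4ccc(Cl)c(Cl)c4)c3)cc2-c2ccncc2)c1` differs from compound 3 by a single change: chloro in place of trifluoromethyl on an aromatic carbon. Within the data shown here, the one measured step that bears on this exchange is a number 36 percentage points higher from compound 1 to compound 2 (beyond the scatter), a large shift toward weaker effect; the other known step, a number 3 percentage points higher from compound 1 to compound 3 (within the scatter), concerns a different change. A weakening of similar size is therefore expected, estimated as a number 35 percentage points higher from compound 3 to compound 4 (beyond the scatter). Compound 4 is expected to give about -50%, within a range from -72% to -25%.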

Compound 4, a percentage reported as activity, at one concentration (the size of the read-out at that concentration, not a potency): -70%
Compound 4: middle estimate off by 20 percentage points, on the high side; the measured number falls inside the stated range.
By their numbers in this assay, from the lowest: compounds 1 and 3 (each within the scatter of the next); then compound 4; then compound 2.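

With the methyl on the oxygen in place, exchanging trifluoromethyl for chloro gives a number 15 percentage points higher from compound 3 to compound 4 (beyond the scatter), so the loss of effect persists but is smaller. The size of this step in this assay therefore depends on the group on the oxygen: the same change on two cores in this assay, a number 36 percentage points higher (beyond the scatter) from compound 1 to compound 2 and a number 15 percentage points higher (beyond the scatter) from compound 3 to compound 4, 21 percentage points apart, beyond the scatter of two such steps

Read the other way, adding that methyl changes the number clearly only when chloro replaces trifluoromethyl, giving a number 18 percentage points lower from compound 2 to compound 4 (beyond the scatter), so the two changes do not simply add: the same change on two cores in this assay, a number 3 percentage points higher (within the scatter) from compound 1 to compound 3 and a number 18 percentage points lower (beyond the scatter) from compound 2 to compound 4, 21 percentage points apart, beyond the scatter of two such steps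

Going by these compounds, whether a bromo or a nitrile at this position would behave like chloro or like trifluoromethyl remains open. So does whether the same dependence would hold with an ethyl group on the oxygen.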